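The compounds below may be only part of what the source reports. "The series", "measured", "known", "first", "only" and "open" are said of these compounds alone.

Compound 2 `CN1CCN(C(=S)SCc2ccc(C(=O)Nc3ccccc3N)cc2)CC1` and compound 1 `Nc1ccccc1NC(=O)c1ccc(CSC(=S)N2CCCc3ccccc32)cc1` share the same core and differ only in the amine attached to the thiocarbonyl carbon. In a functional assay on MGC-803 cells (Homo sapiens) for antiproliferative activity, read by CCK-8 assay, with a stated time of 72 h, tested at 8 uM (on this read-out higher numbers stand for a stronger effect at the one concentration tested and lower numbers for a weaker effect), compound 2 gives 84.4%, while compound 1 gives 87.5%. For the measured compounds named here, of the two numbers recorded, the one for compound 2 stands lowest, yet the gap a number 3.1 percentage points lower from compound 1 to compound 2 (within the scatter) lies within the ordinary scatter of repeated measurements, so the two cannot be separated. Compound 3 `Nc1ccccc1NC(=O)c1ccc(CSC(=S)N2CCCC2)cc1` is the next member, with pyrrolidin-1-yl in place of 4-methylpiperazin-1-yl on a thiocarbonyl carbon. Going by the values given here, the only measured step that bears on this change is the earlier exchange of one amine for another on the same thiocarbonyl carbon, which moved the read-out by a number 3.1 percentage points lower from compound 1 to compound 2 (within the scatter), a shift inside the scatter. A further swap of the amine at that position is therefore expected to change little. The expected step is a number 0.4 percentage points lower from compound 2 to compound 3 (within the scatter), within the scatter. Compound 3 is estimated at 84% in this assay, between 70% and 95%.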

Compound 3, a percentage reported as inhibition, at one concentration (the size of the read-out at that concentration, not a potency): 83.4%
Estimate against measurement, compound 3: 0.6 percentage points above; the measured number falls inside the stated range.
By their numbers in this assay, from the lowest: compounds 3, 2 and 1 (each within the scatter of the next).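

In this assay, pyrrolidin-1-yl, a five-membered ring with 1 hetero atom, in place of 4-methylpiperazin-1-yl, a six-membered ring with 2, gives a number 1 percentage points lower from compound 2 to compound 3 (within the scatter) and so does not separate the two compounds. Pyrrolidin-1-yl in place of 1,2,3,4-tetrahydroquinolin-1-yl gives a number 4.1 percentage points lower from compound 1 to compound 3 (within the scatter) and does not separate that pair either, so all three ring amines on the thiocarbonyl carbon read alike at this one concentration. No measurement shown here offers an explanation for this.

On these data alone, all three compounds carry a ring amine at this place, so it remains open how an open-chain amine such as diethylamino, or a ring amine bearing a carboxylic acid, would read. A single concentration also leaves open whether the three differ in potency.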